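Swapping the Phenol Ring for a Pyrrolidinone Chain

The source may hold more compounds than are shown below. What is called first, only, known or untested is meant among the compounds shown, and "the series" means these compounds.

Compound 1 `C=C(CC)C(=O)c1ccc(OCC(=O)Nc2ccc(O)cc2)c(Cl)c1Cl`: 6400 nM
Compound 2 `C=C(CC)C(=O)c1ccc(OCC(=O)Nc2ccc(S(=O)(=O)O)cc2)c(Cl)c1Cl`: > 25000 nM (a limit)
Compound 3 `C=C(CC)C(=O)c1ccc(OCC(=O)Nc2ccc(/C=C/C(=O)O)cc2)c(Cl)c1Cl`: 3000 nM

In a functional assay on CLL cells (Homo sapiens) for cytotoxicity, read by MTT assay, with a stated time of 48 h (a higher number here means that more compound is needed for the effect, a lower number that less compound is needed), compound 1 gives 6400 nM, the highest of the two numbers, with compound 3 nearest at a 2.1-fold lower number from compound 1 to compound 3 (0.33 log units; beyond the scatter). Compound 2 reaches only a limit, (the limit of > 25000 nM in this assay, at which 1 of the 3 values shown sits). Compound 4 `C=C(CC)C(=O)c1ccc(OCC(=O)NCCCN2CCCC2=O)c(Cl)c1Cl` is not yet measured; it differs from compound 1 as 3-(2-oxopyrrolidin-1-yl)propyl in place of 4-hydroxyphenyl on an amide-type nitrogen. The measured steps, an at least 3.9-fold higher number from compound 1 to compound 2 (0.59 log units; beyond the scatter), a 2.1-fold lower number from compound 1 to compound 3 (0.33 log units; beyond the scatter) and an at least 8.3-fold lower number from compound 2 to compound 3 (0.92 log units; beyond the scatter), all keep the aromatic ring on the amide nitrogen and change only the group on it, so none of them shows what happens when that ring is removed altogether. They give no direct guide, only a sense that the amide substituent can move the number by modest amounts in either direction. Compound 4 is therefore expected near the number of compound 1, estimated at 9000 nM within 3000 nM to 30000 nM, a step of a 1.4-fold higher number from compound 1 to compound 4 (0.15 log units; within the scatter).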

Compound 4, half-maximal effective concentration: 13800 nM
The estimate for compound 4 lay 1.5-fold (0.19 log units) below the measured number, and the stated range covers the measured number.
By their numbers in this assay, from the lowest: compound 3; then compound 1; then compound 4. At a limit, above all of these: compound 2.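

Until now, every step changed only the group carried on the aromatic ring; here the ring itself leaves the amide nitrogen, and in this assay this gives a 2.2-fold higher number from compound 1 to compound 4 (0.33 log units; beyond the scatter). The 4-hydroxyphenyl group can therefore be replaced on this nitrogen by a chain ending in a five-membered non-aromatic ring, and the number moves only modestly, so an aromatic ring at this place is not essential for a measurable effect in this assay. Nothing measured here explains the shift.

The compounds shown leave open whether the change in the number follows from losing the aromatic ring, from gaining the pyrrolidinone, or from the length of the chain. A plain propyl chain, a 3-aminopropyl chain or a shorter ethyl link to the same pyrrolidinone on this nitrogen would help to tell these apart.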